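Cytotoxicity notes on the hexanoate ether amide series

The compounds below may be only part of what the source reports. "The series", "measured", "known", "first", "only" and "open" are said of these compounds alone.

Measured compounds in an ADME assay on HepG2 cells (Homo sapiens) for cytotoxicity, read by CellTiter-Glo and resazurin assay, with a stated time of 72 h; a lower number here means that less compound is needed, a higher number that more compound is needed for the effect:
Compound 1 `CCOC(=O)CCCCCOc1cccc(CN(C(=O)c2ccc(-c3cccc4ccccc34)cc2)C(C)C)c1` gives > 26000 nM, which is a limit of the assay.
Compound 2 `CCOC(=O)CCCCCOc1cccc(CN(C(=O)c2ccc(-c3ccco3)cc2)C(C)C)c1` gives > 26000 nM, which is a limit of the assay.
Compound 3 `CCOC(=O)CCCCCOc1cccc(CN(C(=O)c2ccc(-c3cccc(O)c3)cc2)C(C)C)c1` gives > 26000 nM, which is a limit of the assay.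

All three measured compounds sit at the same limit in this assay, so no order among them can be read. The step that the two limits leave unreadable from compound 1 to compound 2 and the step that the two limits leave unreadable from compound 1 to compound 3 are both unreadable in size, and so is the step that the two limits leave unreadable from compound 2 to compound 3. Compound 3 thus stands at the limit together with both other compounds, as the summary the limit of > 26000 nM in this assay, at which 3 of the 3 values shown sit, states.

Compound 4 `CCOC(=O)CCCCCOc1cccc(CN(C(=O)c2ccc(-c3cccc(OC(F)(F)F)c3)cc2)C(C)C)c1` differs from compound 3 by trifluoromethyl in place of hydrogen on an oxygen on an aromatic ring. Among the measured compounds shown here, no measured step bears directly on this change; the only evidence is that every measured compound in this assay, whatever the aryl group on the aromatic carbon, reports a limit. The expectation for compound 4 is therefore that the step that the limit leaves unreadable from compound 3 to compound 4 stays within the scatter, with the result most likely again reported as a limit rather than a number. For compound 4 the estimated value in this assay is 40000 nM, with a range from 15000 nM to 150000 nM.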

Compound 4, half-maximal effective concentration: > 26000 nM
Compound 4 gave a limit, no number; the forecaster's own chance of this, stated with the estimate: 85%; the middle value lies beyond the limit too.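

In this assay compound 4 gives > 26000 nM, which is a limit of the assay and not a number. No step linking compound 4 with compound 1, compound 2 or compound 3 can be read, and the series stands at one value: the limit of > 26000 nM in this assay, at which 4 of the 4 values shown sit.

The compounds shown leave open whether any change to the aryl group on the shared core would give a measurable value in this assay.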